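Isopropyl to methyl across two basic side chains

The source may hold more compounds than are shown below. What is called first, only, known or untested is meant among the compounds shown, and "the series" means these compounds.

In an ADME assay (liver) for metabolic stability, with Liver microsome (Homo sapiens) as the target, read by LC-MS, using microsomes, tested at 1 uM (on this read-out higher numbers stand for a longer-lived compound and lower numbers for a shorter-lived compound), compound 2 `CC(C)/C(=N/c1ccnc2cc(Cl)ccc12)NCCCN1CCCCC1` gives 0.483 h. Compound 1 `C/C(=N/c1ccnc2cc(Cl)ccc12)NCCCN1CCCCC1` is reported only as a limit, > 1 h, as noted in the limit of > 1 h in this assay, at which 1 of the 3 values shown sits. The step of an at least 2.0-fold higher number from compound 2 to compound 1 (0.31 log units; beyond the scatter) corresponds to the change (methyl in place of isopropyl on a carbon with a double bond to nitrogen). Compound 3 `CCN(CC)CCCCN/C(=N\c1ccnc2cc(Cl)ccc12)C(C)C` gives 0.917 h in this assay; the step of a 1.9-fold higher number from compound 2 to compound 3 (0.28 log units; within the scatter) rests on the difference between the two cores, ((diethylamino)methyl in place of piperidin-1-yl on a saturated chain carbon, three bonds along the chain from an amine nitrogen). Compound 4 `CCN(CC)CCCCN/C(C)=N\c1ccnc2cc(Cl)ccc12` has not been measured in this assay. It differs from compound 3 by methyl in place of isopropyl on a carbon with a double bond to nitrogen, the same change as from compound 2 to compound 1, at a place described in identical words. For the measured compounds named here, the step of a 2.0-fold higher number from compound 3 to compound 4 (0.29 log units; within the scatter) is expected to be of a size like an at least 2.0-fold higher number from compound 2 to compound 1 (0.31 log units; beyond the scatter), since that step is the only measured instance of this change. Compound 4 is therefore estimated at 1.8 h, with a range from 0.9 h to 4 h, and the measurement is expected to fall at the assay limit rather than give a number.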

Compound 4, half-life: > 1 h
Compound 4: a limit, no number; the forecaster's own chance of this, stated with the estimate: 60%; the middle value lies beyond the limit too.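

In this assay compound 4 is reported only as a limit, > 1 h, not as a number. On the core of compound 3, methyl in place of isopropyl gives an at least 1.0-fold higher number from compound 3 to compound 4 (0.03 log units; that floor lies within the scatter), which is only a floor, and the step between compound 1 and compound 4 cannot be read. Neither core gives a lower number with this change, but that does not show that its size carries from one core to the other: the same change on two cores in this assay, an at least 2.0-fold higher number (0.31 log units; beyond the scatter) from compound 2 to compound 1 and an at least 1.0-fold higher number (0.03 log units; that floor lies within the scatter) from compound 3 to compound 4; the limit leaves it open whether they differ

As far as these compounds go, the true half-lives of compound 1 and compound 4 remain open, so the two side chains cannot be ranked with methyl in place. Also open is how an ethyl or cyclopropyl group would read on a carbon with a double bond to nitrogen, where only isopropyl and methyl are shown.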